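The compounds below may be only part of what the source reports. "The series", "measured", "known", "first", "only" and "open" are said of these compounds alone.

Values in an ADME assay on cells (Hepatocyte, Rattus norvegicus) for metabolic stability; a lower number here means that the compound disappears faster, a higher number that the compound lasts longer:
- compound 1 `N#Cc1cnc(N2CCC(C(=O)N3N=CC[C@H]3c3cc(F)cc(F)c3)CC2)cn1`: 1.78 h
- compound 2 `Cc1nnc(N2CCC(C(=O)N3N=CC[C@H]3c3cc(F)cc(F)c3)CC2)o1`: 3.3 h
- compound 3 `N#Cc1nccc(N2CCC(C(=O)N3N=CC[C@H]3c3cc(F)cc(F)c3)CC2)n1`: not yet measured

In this assay, among the compounds with values here, compound 2 gives 3.3 h, which lies within the scatter of compound 1, the only other measured compound. The next change is 2-cyanopyrimidin-4-yl in place of 5-methyl-1,3,4-oxadiazol-2-yl on an amine nitrogen in a ring. In words, this puts 2-cyanopyrimidin-4-yl in place of 5-methyl-1,3,4-oxadiazol-2-yl on an amine nitrogen in a ring.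

Within the data shown here, only one measured step bears on this: a 1.9-fold higher number from compound 1 to compound 2 (0.27 log units; within the scatter). It exchanges 5-cyanopyrazin-2-yl for the same 5-methyl-1,3,4-oxadiazol-2-yl at the same place. Among the measured compounds shown here, no measured compound carries 2-cyanopyrimidin-4-yl, so the closest comparison is compound 1, with its 5-cyanopyrazin-2-yl group and 1.78 h. A single step is thin support, and a step beyond the scatter is not expected in this assay. The expected shift is a 1.7-fold lower number from compound 2 to compound 3 (0.22 log units; within the scatter), and it is estimated to remain within the scatter. The estimate for compound 3 is 2 h, with an expected range from 0.9 h to 4.2 h.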

Compound 3, half-life: 0.917 h
The estimate for compound 3 lay 2.2-fold (0.34 log units) above the measured number; the range from low to high includes it.
By their numbers in this assay, from the lowest: compounds 3, 1 and 2 (each within the scatter of the next, the first and the last beyond it).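

In this assay, this place on the amine nitrogen in a ring now gives a step beyond the scatter, which the first pair did not: a 3.6-fold lower number from compound 2 to compound 3 (0.56 log units; beyond the scatter), a modest change. The two nitrile-bearing groups cannot be told apart, with a 1.9-fold lower number from compound 1 to compound 3 (0.29 log units; within the scatter), so only compound 3 separates from the 5-methyl-1,3,4-oxadiazol-2-yl group of compound 2, while compound 1 stays within the scatter of compound 2 and the three compounds form no clear ranking by group. Nothing available explains the separation of compound 3 from compound 2.

Open, as far as these compounds go, is how a pyrimidin-4-yl group without the nitrile, or with a methoxy group in its place, would compare with compound 3 in this assay, a comparison that would separate the contribution of the nitrile from that of the ring. Also open is whether the step from 5-methyl-1,3,4-oxadiazol-2-yl to 2-cyanopyrimidin-4-yl keeps its direction and size on any other core, since all three compounds shown share a single core.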